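Chloro for hydrogen on the phenylsulfonyl group, second instance

This account rests on a few compounds, and the source may have more. Where it says the series, first, only, none or still open, it means among the compounds named here.

Measured so far in a functional assay on MCF7 cells (Homo sapiens) for inhibition, read by MTT assay, with a stated time of 48 h; a higher number here means a weaker inhibitor, a lower number a stronger inhibitor:
compound 1, `COc1ccc(-n2cc(NC(=O)c3cccc(NS(=O)(=O)c4ccccc4)c3)cn2)cc1`, 18700 nM
compound 2, `COc1ccc(-n2cc(NC(=O)c3cccc(NS(=O)(=O)c4ccc(Cl)cc4)c3)cn2)cc1`, 8720 nM
compound 3, `Cc1ccc(-n2cc(NC(=O)c3ccc(NS(=O)(=O)c4ccccc4)cc3)cn2)cc1`, 10900 nM

Compound 1 to compound 2 is a single change, (chloro in place of hydrogen on an aromatic carbon), and it gave a 2.1-fold lower number from compound 1 to compound 2 (0.33 log units; beyond the scatter). Compound 3 shares this pattern of an amide and a sulfonylamino group but differs from compound 1 in more than one place; the difference between the two cores is not broken down here. Compound 2 and compound 3 give numbers within the scatter of each other.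

Compound 4, `Cc1ccc(-n2cc(NC(=O)c3ccc(NS(=O)(=O)c4ccc(Cl)cc4)cc3)cn2)cc1`, is not yet measured. It differs from compound 3 by chloro in place of hydrogen on an aromatic carbon, the same change as from compound 1 to compound 2, at a place described in the same words. Among the compounds with values here, only that one earlier step is available, so the expectation for compound 4 rests on it alone: a step of about a 2.0-fold lower number from compound 3 to compound 4 (0.30 log units; within the scatter) is expected, beside the earlier 2.1-fold lower number from compound 1 to compound 2 (0.33 log units; beyond the scatter). Compound 4 is therefore estimated at 5500 nM in this assay, with a likely range from 2500 nM to 12000 nM.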

Compound 4, half-maximal inhibitory concentration: 3990 nM
For compound 4 the middle estimate is 1.4-fold (0.14 log units) above the measured one; the range from low to high includes it.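

In this assay the change from phenylsulfonyl to (4-chlorophenyl)sulfonyl gives a 2.7-fold lower number from compound 3 to compound 4 (0.44 log units; beyond the scatter) and runs the same way as on the core of compound 1. The two steps agree in size: the same change on two cores in this assay, a 2.1-fold lower number (0.33 log units; beyond the scatter) from compound 1 to compound 2 and a 2.7-fold lower number (0.44 log units; beyond the scatter) from compound 3 to compound 4, 1.3-fold (0.11 log units) apart, within the scatter of two such steps. This supports carrying the change between these two cores only; two pairs in one cell assay do not show that it holds on other cores, and they do not show why the number falls.

The compounds shown leave open whether fluoro, an amine or a carboxylic acid in place of chloro would move the number in the same way. As far as these compounds go, the two cores differ in more than one place, so what each difference contributes also stays open.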